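Reading an imidazole swap in the acid dissociation series

The compounds below may be only part of what the source reports. "The series", "measured", "known", "first", "only" and "open" are said of these compounds alone.

Going by the values given here, in a physicochemical assay for acid dissociation, compound 1 `C(C#Cc1ccncc1)#Cc1ccccc1` gives 3.3 and holds the only number in this small series. Compound 2 `C(C#Cc1ncc[nH]1)#Cc1ccccc1` stands at "not determined" (no result reported) in this assay and so offers no single number to start from. Compound 3 `C(C#Cc1c[nH]cn1)#Cc1ccccc1` awaits measurement. The structural change is 1H-imidazol-4-yl in place of 1H-imidazol-2-yl on a triple-bonded carbon with 1H-imidazol-4-yl in place of 1H-imidazol-2-yl on a triple-bonded carbon.

Without a number for compound 2, the size of this step cannot be read from data. A modest rise in this assay is expected, beyond the usual scatter, though nothing measured yet supports it. Compound 3 is also expected to read higher than compound 1, the sole numerical anchor. For compound 3 the estimated value is 4.5 with an expected range from 3.5 to 5.5 in this measurement.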

Compound 3, acid dissociation constant: 4
Compound 3: middle estimate off by 0.50 log units, on the high side; the range from low to high includes it.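

No step can be read from compound 2 to compound 3: in this assay compound 2 stands at "not determined" (no result reported), while compound 3 gives 4. The compounds shown leave open how far 1H-imidazol-4-yl in place of 1H-imidazol-2-yl shifts this read-out. Nothing available bears on the result.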